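A carboxy-bearing amide on compound 2

The compounds below may be only part of what the source reports. "The series", "measured", "known", "first", "only" and "open" are said of these compounds alone.

Values measured in a functional assay on HepG2 cells (Homo sapiens), read by MTT assay, with a stated time of 48 h (a lower number here means a stronger inhibitor, a higher number a weaker inhibitor), are these
- compound 1 `CCn1c(C(=O)NCCN(C)C)ccc1C(CC)(CC)c1ccc(OCC(=O)C(C)(C)C)c(C)c1` gives 2300 nM
- compound 2 `CCn1c(C(=O)NCC(OC)OC)ccc1C(CC)(CC)c1ccc(OCC(O)C(C)(C)C)c(C)c1` gives 23200 nM
- compound 3 `CCn1c(C(=O)N(C)CC(=O)O)ccc1C(CC)(CC)c1ccc(OCC(=O)C(C)(C)C)c(C)c1` gives 25200 nM

Compound 2 lies within the scatter of compound 3 and carries a clearly higher number than compound 1. The next compound to be read is compound 4 `CC[C@@H](C)[C@H](NC(=O)c1ccc(C(CC)(CC)c2ccc(OCC(O)C(C)(C)C)c(C)c2)n1CC)C(=O)O`, in which 1-carboxy-2-methylbutyl takes the place of 2,2-dimethoxyethyl on an amide-type nitrogen (1-carboxy-2-methylbutyl in place of 2,2-dimethoxyethyl on an amide-type nitrogen). For the measured compounds named here, one measured step bears on this change. It brings in (carboxymethyl)(methyl)amino in place of (2-(dimethylamino)ethyl)amino, and it is large and beyond the scatter an 11-fold higher number from compound 1 to compound 3 (1.04 log units; beyond the scatter). That step, however, ends at a number that compound 2 already shares within the scatter, since compound 3 stands at 25200 nM even though the two differ elsewhere as well. No step beyond the scatter is therefore expected in this assay, and the expected change is small a 1.1-fold higher number from compound 2 to compound 4 (0.05 log units; within the scatter). For compound 4 the estimated value is 26000 nM, with an expected range from 10000 nM to 65000 nM.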

Compound 4, half-maximal inhibitory concentration: 127 nM
Compound 4: middle estimate off by 200-fold (2.31 log units), on the high side; the whole stated range lies above it.
By their numbers in this assay, from the lowest: compound 4; then compound 1; then compounds 2 and 3 (each within the scatter of the next).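

In this assay, the group on the amide-type nitrogen can move the number far downward: 1-carboxy-2-methylbutyl in place of 2,2-dimethoxyethyl gives a 180-fold lower number from compound 2 to compound 4 (2.26 log units; beyond the scatter). For the compounds shown here, the only earlier step at this amide ran the other way, an 11-fold higher number from compound 1 to compound 3 (1.04 log units; beyond the scatter), so a carboxy-bearing group here is not tied to a higher number, although that step involves different groups on a different background from the new one. No measurement given here explains the size of this drop.

The change replaces the whole group, so the carboxylic acid, the branched chain and the two defined stereocentres all enter together and cannot be told apart. On these data alone, whether a plain 2-methylbutyl chain without the acid, or a methyl ester of that acid, would stand nearer compound 4 or compound 2 remains open.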